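Notes on a naphthyl-pyridine series: acrylamide to hydrazide

A few compounds are considered here, and "the series" means these few. Any claim that something is new, unique, unknown or untested is made for them only; others in the source may bear on it.

Measured compounds:
compound 1, `Cn1ccc2cc(-c3cnccc3/C=C/C(=O)O)ccc21`, 7260 nM
compound 2, `CNC(=O)/C=C/c1ccncc1-c1ccc2ccccc2c1`, 6550 nM
compound 3, `O=C(O)[C@@H]1CCCN1C(=O)/C=C/c1ccncc1-c1ccc2ccccc2c1`, "not determined" (no result reported)

In a functional assay on HCT-116 cells (Homo sapiens) for inhibition, read by MTT assay, with a stated time of 72 h (a lower number here means a stronger inhibitor of growth, a higher number a weaker inhibitor of growth), compound 2 gives 6550 nM. Compound 1 gives 7260 nM in this assay, and the two numbers sit within the usual scatter of each other, so no order between them can be claimed. Compound 2 has the lowest of the two numbers recorded, with compound 1 its nearest neighbour and compound 3 carrying no number at all.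

Compound 4, `NNC(=O)CCc1ccncc1-c1ccc2ccccc2c1`, is the next member to be read in this assay. Compared with compound 2 it shows (2-(aminocarbamoyl)ethyl in place of 2-(methylcarbamoyl)ethenyl on an aromatic carbon). The change exchanges the 2-(methylcarbamoyl)ethenyl for the 2-(aminocarbamoyl)ethyl and so removes one of the 2 double bonds outside aromatic rings while adding a hydrogen-bond donor and acceptor; the rest of the structure is kept.

Within the data shown here, no measured pair with a single change of this kind is available, so the size of the step is uncertain. The expected outcome is a small weakening, at the edge of the scatter, with a step of a 1.8-fold higher number from compound 2 to compound 4 (0.26 log units; within the scatter). Compound 4 is estimated at 12000 nM, with a likely range from 4000 nM to 40000 nM.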

Compound 4, concentration for 50% growth inhibition: > 30000 nM
Compound 4: a limit, no number (the forecaster's own chance of this, stated with the estimate: 15%); middle value at least 2.5-fold (0.39 log units) away from the limit.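

Compound 4 reads > 30000 nM in this assay, and this is a limit of the assay, not a number. Among these compounds, exchanging the 2-(methylcarbamoyl)ethenyl for the 2-(aminocarbamoyl)ethyl on the aromatic carbon opposite the ring nitrogen gives an at least 4.5-fold higher number from compound 2 to compound 4 (0.66 log units; beyond the scatter), the first step between compounds that differ in one place, and it shows that growth inhibition responds to a change at this position. The step is open-ended, so it fixes only a lower bound on the loss and not its size: the limit of > 30000 nM in this assay, at which 1 of the 4 values shown sits.

The compounds shown do not separate the two parts of this change, the loss of the chain double bond and the exchange of the methylamide end for the hydrazide end. As far as these compounds go, a saturated 2-(methylcarbamoyl)ethyl or an unsaturated 2-(aminocarbamoyl)ethenyl at this position would pull the two apart, and the effect of a free carboxylic acid on the same chain of the core of compound 2 also remains open.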